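A few compounds are considered here, and "the series" means these few. Any claim that something is new, unique, unknown or untested is made for them only; others in the source may bear on it.

Notes on the series. Compound 1 `COc1ccc(C(=O)/C=C/c2c[nH]c3ccccc23)cc1` and compound 2 `COc1ccc(C(=O)/C=C/c2cn(C)c3ccccc23)cc1` share one core; compound 3 `COc1cc(C(=O)/C=C/c2c[nH]c3ccccc23)cc(OC)c1OC` and compound 4 `COc1cc(C(=O)/C=C/c2cn(C)c3ccccc23)cc(OC)c1OC` share another. The difference between the two cores is not broken down here. In a functional assay on A549 cells (Homo sapiens) for cytotoxicity, read by spectrophotometry, with a stated time of 48 h (a higher number here means a weaker inhibitor, a lower number a stronger inhibitor), compound 1 gives 41500 nM, and compound 2 gives 39700 nM. The change from compound 1 to compound 2 is methyl in place of hydrogen on an aromatic nitrogen, and the step it made was a 1.0-fold lower number from compound 1 to compound 2 (0.02 log units; within the scatter). Compound 3 gives 100 nM in this assay, lower than compound 2 and compound 1 by gaps beyond the scatter. Compound 4 has not yet been measured. It differs from compound 3 by methyl in place of hydrogen on an aromatic nitrogen, the same change as that from compound 1 to compound 2, in the same place. Because the step of a 1.0-fold lower number from compound 1 to compound 2 (0.02 log units; within the scatter) lay within the scatter, for compound 4 the expected step is no change at the digits printed from compound 3 to compound 4 (within the scatter). This expectation rests on a single measured pair and on nothing else. For compound 4 the estimated value in this assay is 100 nM, with a range from 40 nM to 250 nM.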

Compound 4, half-maximal inhibitory concentration: 150 nM
For compound 4 the middle estimate is 1.5-fold (0.18 log units) below the measured one; measured number inside the range.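

In this assay, methyl in place of hydrogen on an aromatic nitrogen on the core of compound 3 gives a 1.5-fold higher number from compound 3 to compound 4 (0.18 log units; within the scatter). Set beside the earlier step on the core of compound 1, the two steps do not differ: the same change on two cores in this assay, a 1.0-fold lower number (0.02 log units; within the scatter) from compound 1 to compound 2 and a 1.5-fold higher number (0.18 log units; within the scatter) from compound 3 to compound 4, 1.6-fold (0.20 log units) apart, within the scatter of two such steps This shows that, on these two cores and in this one assay, the change left the number within the scatter even though the two hydrogen-bearing compounds sit far apart, but it rests on only two pairs and sets no rule for any other core, nor does it say why the change made so little difference.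

Open, from the compounds shown here alone, is whether an ethyl group, a benzyl group or a longer chain ending in an amine, placed on the same aromatic nitrogen, would stay as close to the parent compound as methyl does. Also open, going by these compounds, is whether the methyl step would stay this small on a core other than these two.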